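Cyclohexylethyl in place of pentyl on the urea-type chain

This account rests on a few compounds, and the source may have more. Where it says the series, first, only, none or still open, it means among the compounds named here.

Measured compounds:
compound 1, `CCCCCCNC(=O)/N=C(\N)NCCCc1sc(N)nc1C`, 85.1 nM
compound 2, `Cc1nc(N)sc1CCCN/C(N)=N/C(=O)NC(C)c1ccco1`, 234 nM

In a functional assay on HEK293T cells for agonist activity at histamine H2 receptor (Homo sapiens), read by beta-arrestin recruitment (a higher number here means that more compound is needed for the effect, a lower number that less compound is needed), compound 1 gives 85.1 nM, the lower of the two numbers measured; the nearest is compound 2, whose value in this assay is 234 nM. For the measured compounds named here, the only measured step is a 2.7-fold higher number from compound 1 to compound 2 (0.44 log units; beyond the scatter), where a ring-bearing group replaces the hexyl on the amide-type nitrogen. Compound 3, `Cc1nc(N)sc1CCCN/C(N)=N/C(=O)NCC(C)C1CCCCC1`, has not yet been measured. It differs from compound 1 as follows: 1-cyclohexylethyl in place of pentyl on a saturated chain carbon bound to an amide-type nitrogen. This change also puts a ring-bearing group in the place of a plain chain, so the step to compound 2 is the one that bears on it, and a modest rise in this assay of similar size is expected, though not assured. For compound 3 the value in this assay is estimated at 150 nM, within 60 nM to 400 nM. This means an expected step of a 1.8-fold higher number from compound 1 to compound 3 (0.25 log units; within the scatter).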

Compound 3, half-maximal effective concentration: 224 nM
Estimate against measurement, compound 3: 1.5-fold (0.17 log units) below; the range from low to high includes it.
By their numbers in this assay, from the lowest: compound 1; then compounds 3 and 2 (each within the scatter of the next).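

In this assay, the change to 1-cyclohexylethyl in place of pentyl on a saturated chain carbon bound to an amide-type nitrogen gives (a 2.6-fold higher number from compound 1 to compound 3 (0.42 log units; beyond the scatter)), so a higher number at this position is now seen with a saturated carbon ring as well as with the furan-bearing group. Compound 3 at 224 nM and compound 2 at 234 nM stand within the scatter of each other, so these two ring-bearing groups cannot be told apart here, and compound 1 with its open chain keeps the lowest number of the three. Nothing among the data given explains the rise.

The compounds shown leave open whether the ring itself or the branching in these groups goes with the higher number, which an unbranched 2-cyclohexylethyl group would help to separate. They also leave open how a phenyl group or a chain longer than hexyl would read at this position.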